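Ester chain variation in a bicyclic nucleoside series

This account rests on a few compounds, and the source may have more. Where it says the series, first, only, none or still open, it means among the compounds named here.

Compound 2 `CCCCOC(=O)[C@@]12C[C@@H]1[C@@H](n1cnc3c(NC)nc(C#Cc4ccc(Cl)s4)nc31)[C@H](O)[C@@H]2O` gives the higher of the two numbers measured in an assay on HEK-293T cells for displacement of a labelled ligand from transmembrane domain-containing protein TMIGD3 (Homo sapiens), read by scintillation counting and radioligand binding, with stated times of 10 min and 90 min; a lower number here means a stronger inhibitor, a higher number a weaker inhibitor: compound 2 gives 17.5 nM, whereas compound 1 `CCOC(=O)[C@@]12C[C@@H]1[C@@H](n1cnc3c(NC)nc(C#Cc4ccc(Br)s4)nc31)[C@H](O)[C@@H]2O` gives 6.42 nM. Compound 1 and compound 2 differ from each other in more than one place, so only their two values are noted; the gap between them lies beyond the scatter. Compound 3 `CNc1nc(C#Cc2ccc(Cl)s2)nc2c1ncn2[C@H]1[C@H](O)[C@H](O)[C@]2(C(=O)OCCc3ccccc3)C[C@H]12` keeps the core of compound 2 and changes a single group: phenyl in place of ethyl on a saturated chain carbon, two bonds along the chain from an oxygen next to a carbonyl group. Among the compounds with values here, no measured pair differs only in this way, so there is no measured step to guide the expectation. The step from compound 2 to compound 3 is expected to be small, with a modestly higher number, and is estimated as a 1.3-fold higher number from compound 2 to compound 3 (0.10 log units; within the scatter). Compound 3 is therefore expected to give 22 nM in this assay, within a range from 7 nM to 70 nM.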

Compound 3, inhibition constant: 262 nM
Beside the measured number, compound 3's estimate is 12-fold (1.08 log units) below it; the measured number lies above the stated range.
By their numbers in this assay, from the lowest: compound 1; then compound 2; then compound 3.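

The ester chain at this position does not accept every change equally: phenyl in place of ethyl, on a saturated chain carbon, two bonds along the chain from an oxygen next to a carbonyl group, gives a 15-fold higher number from compound 2 to compound 3 (1.18 log units; beyond the scatter) in this assay and is a large step. Within the data shown here, this is the first change that can be read in one place, and it shows that going from a butyl to a phenethyl ester is enough to move the number well beyond the scatter. No measured data bear on the origin of this step.

Still open, on these data alone, is whether the step follows from the aromatic ring itself, which a cyclohexylethyl ester would test, or from chain length, which a hexyl ester would test. The free carboxylic acid and a benzyl ester at this place also remain unplaced.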